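This account rests on a few compounds, and the source may have more. Where it says the series, first, only, none or still open, it means among the compounds named here.

For the measured compounds named here, compound 2 `CNc1c(C)c(C(OC(C)(C)C)C(=O)O)c(-c2ccc(C)c(C)c2)c(C)c1-c1ccc(C)c(C)c1` stands at 8800 nM in an ADME assay on MT4 cells (Homo sapiens) for cytotoxicity, read by MTT assay, with a stated time of 4 days (a higher number here means that more compound is tolerated, a lower number that less compound is tolerated), within the scatter of its only neighbour compound 1 `Cc1ccc(-c2c(C)c(-c3ccc(C)c(C)c3)c(C(OC(C)(C)C)C(=O)O)c(C)c2NS(C)(=O)=O)cc1C`, which stands at 15000 nM; the step of a 1.7-fold lower number from compound 1 to compound 2 (0.23 log units; within the scatter) comes from methyl in place of methylsulfonyl on a nitrogen on an aromatic ring. Compound 3 `CCNC(=O)Nc1c(C)c(C(OC(C)(C)C)C(=O)O)c(-c2ccc(C)c(C)c2)c(C)c1-c1ccc(C)c(C)c1` carries ethylcarbamoyl in place of methyl on a nitrogen on an aromatic ring. Going by the values given here, no measured step alters this nitrogen substituent in that way; the one step touching it, a 1.7-fold lower number from compound 1 to compound 2 (0.23 log units; within the scatter), stays within the scatter, so no movement beyond the scatter is expected in this assay. Compound 3 is expected at 10000 nM, with a range of 4000 nM to 30000 nM. The expected step is a 1.1-fold higher number from compound 2 to compound 3 (0.06 log units; within the scatter).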

Compound 3, half-maximal cytotoxic concentration: 15000 nM
Estimate against measurement, compound 3: 1.5-fold (0.18 log units) below; measured number inside the range.
By their numbers in this assay, from the lowest: compounds 2, 1 and 3 (each within the scatter of the next).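

In this assay, the nitrogen on the aromatic ring now also carries ethylcarbamoyl, and the steps stay within the scatter: a 1.7-fold higher number from compound 2 to compound 3 (0.23 log units; within the scatter) and no change at the digits printed from compound 1 to compound 3 (within the scatter). Across these three compounds, five heavy atoms with a hydrogen-bond donor and acceptor in place of methyl or methylsulfonyl produce no movement beyond the scatter. No evidence bears on the reason for this.

On these data alone, whether a longer chain on the ethylcarbamoyl nitrogen, or a carboxylic acid or primary amine at this position, would shift the number remains open. As far as these compounds go, the effect of changes elsewhere on the shared core also remains open.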